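A Third Methoxy on the Carbonyl-Side Ring

A few compounds are considered here, and "the series" means these few. Any claim that something is new, unique, unknown or untested is made for them only; others in the source may bear on it.

Among the measured compounds shown here, compound 2 `COc1ccc(C(=O)/C=C/c2cc(-c3cc(OC)c(OC)c(OC)c3)n[nH]2)cc1OC` gives the only numerical value in a functional assay on MDA-MB-231 cells (Homo sapiens) for inhibition, read by sulforhodamine B assay, with a stated time of 48 h (on this read-out higher numbers stand for weaker inhibition of growth and lower numbers for stronger inhibition of growth), 3060 nM. For compound 1 `COc1cc(-c2cc(/C=C/C(=O)c3ccc(Cl)c(Cl)c3)[nH]n2)cc(OC)c1OC` this assay reports only a limit, > 100000 nM. For the measured compounds named here, the one measured change, an at least 32-fold lower number from compound 1 to compound 2 (1.51 log units; beyond the scatter), swaps the whole aryl group on the carbonyl carbon and so does not probe the addition of a single methoxy. Compound 3 `COc1cc(C(=O)/C=C/c2cc(-c3cc(OC)c(OC)c(OC)c3)n[nH]2)cc(OC)c1OC` differs from compound 2 by methoxy in place of hydrogen on an aromatic carbon. Going by the values given here, with no measured step bearing on this change, a shift in this assay no larger than the usual scatter is expected. Compound 3 is therefore expected to give 2500 nM, within 700 nM to 9000 nM. The expected step is a 1.2-fold lower number from compound 2 to compound 3 (0.09 log units; within the scatter).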

Compound 3, concentration for total growth inhibition: 3800 nM
Compound 3: middle estimate off by 1.5-fold (0.18 log units), on the low side; the range from low to high includes it.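

In this assay, methoxy in place of hydrogen on this aromatic carbon, ortho to a methoxy group and meta to a large group, gives a 1.2-fold higher number from compound 2 to compound 3 (0.09 log units; within the scatter). Compound 2 and compound 3 therefore cannot be told apart, so this is the first shown single-group change on this ring that leaves the read-out within the usual scatter. No information given here explains this outcome.

Going by these compounds, whether an amine, a hydroxyl group or a longer chain such as ethoxy on this carbon would also leave the read-out within the scatter stays open.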